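Removing the Ethyl from the Piperazine Nitrogen of Compound 2

The source may hold more compounds than are shown below. What is called first, only, known or untested is meant among the compounds shown, and "the series" means these compounds.

The measured compounds are compound 1 `CCN1CCN(c2cccc3c2CN([C@H](CCCNCc2cccs2)c2ccc(OC)c(OC)c2)C3=O)CC1`, compound 2 `CCN1CCN(c2cccc3c2CN([C@H](CCCN(C)S(=O)(=O)c2cccs2)c2ccc(OC)c(OC)c2)C3=O)CC1` and compound 3 `COc1cc(Br)c(S(=O)(=O)Nc2ccc(C(F)(F)F)c(O[C@@H]3CCN(C)C3)c2)cc1OC`. In a functional assay on CHO-K1 cells for antagonist activity at Urotensin-2 receptor (Rattus norvegicus), read by FLIPR and calcium flux, with a stated time of 1 h (a higher number here means a weaker inhibitor, a lower number a stronger inhibitor), compound 1 gives 6 nM, compound 2 gives 7 nM and compound 3 gives 34 nM.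

Among these three numbers compound 2 stands second highest. Its nearest neighbour is compound 1, which lies within the scatter of it; compound 3 is furthest, with a number that is clearly higher than that of compound 2. For the measured compounds named here, the only single-point step among the measured compounds is the one at the chain, a 1.2-fold higher number from compound 1 to compound 2 (0.07 log units; within the scatter), and it lies within the scatter.

Compound 4 `COc1ccc([C@@H](CCCN(C)S(=O)(=O)c2cccs2)N2Cc3c(cccc3N3CCNCC3)C2=O)cc1OC` differs from compound 2 at another place altogether: hydrogen in place of ethyl on an amine nitrogen in a ring. Going by the values given here, no measured step touches this ring nitrogen, so there is nothing among the measured compounds that bears directly on the change. With no evidence for a move in either direction, the expectation for this assay is a step no larger than the scatter. Compound 4 is therefore expected to give 12 nM, within a range of 4 nM to 40 nM, which corresponds to an expected step of a 1.7-fold higher number from compound 2 to compound 4 (0.23 log units; within the scatter).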

Compound 4, half-maximal inhibitory concentration: 39 nM
Estimate against measurement, compound 4: 3.3-fold (0.51 log units) below, within the range that was stated.
By their numbers in this assay, from the lowest: compounds 1 and 2 (each within the scatter of the next); then compounds 3 and 4 (each within the scatter of the next).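

In this assay, the change from 4-ethylpiperazin-1-yl to piperazin-1-yl gives a 5.6-fold higher number from compound 2 to compound 4 (0.75 log units; beyond the scatter), which shows that this ring nitrogen is a place where the read-out responds to a change, and that the ethyl cannot be dropped without loss of inhibition. For the compounds shown here, the earlier compounds showed only a step at the chain, a 1.2-fold higher number from compound 1 to compound 2 (0.07 log units; within the scatter), which stayed within the scatter, so this is the first step among the compounds that goes beyond it, and it comes from taking away two carbons and adding no heavy atom. Nothing in the information available explains why the number rises when the ethyl leaves.

The compounds shown leave open how much of the ethyl is needed, since a methyl, a propyl or an acetyl group on this ring nitrogen could show whether the number follows the size of the group or depends on something else. Going by these compounds, the step also rests on a single pair, so it remains open whether the same change would give a step of similar size on compound 1, with its ((thiophen-2-yl)methyl)amino chain.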